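A Dimethoxyphenyl Swap on the Saturated Ring Carbon

The source may hold more compounds than are shown below. What is called first, only, known or untested is meant among the compounds shown, and "the series" means these compounds.

Of the compounds shown here, three have been tested in a functional assay on the whole organism (strain Wistar) for inhibition, with Rattus norvegicus as the target, read by paw edema, with stated times of 30 min and 3 h, at a dose of 20 mg/kg by the oral route; a lower number here means less inhibition, a higher number more inhibition at the dose given (going by the name of the read-out). Compound 1 `COc1ccc(C2CC(c3cc(Cl)c(C)cc3O)=NN2c2ccc(S(N)(=O)=O)cc2)cc1OC` gives 60.5% in this assay, the highest of the three numbers. Compound 2 `COc1cc(C)c(Cl)cc1C1=NN(c2ccc(S(N)(=O)=O)cc2)C(c2ccccc2)C1` gives 55.3%, and compound 3 `COc1cc(C)c(Cl)cc1C1=NN(c2ccc(S(N)(=O)=O)cc2)C(/C=C/c2ccccc2)C1` gives 55.3%, so compounds 2 and 3 stand level at the digits shown and together make up the lowest pair. Compound 3 sits no change at the digits printed from compound 2 to compound 3 (within the scatter), and the gap of compound 3 to compound 1 is within the usual scatter, so none of the three can be separated on these numbers.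

Compound 4 `COc1ccc(C2CC(c3cc(Cl)c(C)cc3OC)=NN2c2ccc(S(N)(=O)=O)cc2)cc1OC` is the next step from compound 3. The change is 3,4-dimethoxyphenyl in place of 2-phenylethenyl on a saturated ring carbon. Going by the values given here, the one measured step at the same position, 2-phenylethenyl in place of phenyl, gave no change at the digits printed from compound 2 to compound 3 (within the scatter), so a change of the group on that saturated ring carbon has so far left the read-out where it was. Among the compounds with values here, there is no measured step that sets 3,4-dimethoxyphenyl against another group at this place, so nothing in the data argues for a move beyond the scatter. Compound 4 is therefore expected to give about 58% in this assay, between 48% and 68%, an estimated step of a number 2.7 percentage points higher from compound 3 to compound 4 (within the scatter) from compound 3.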

Compound 4, a percentage reported as inhibition, in the whole organism at one dose (the size of the read-out at that dose, not a potency): 31.6%
For compound 4 the middle estimate is 26.4 percentage points above the measured one, outside the stated range (below it).
By their numbers in this assay, from the lowest: compound 4; then compounds 2, 3 and 1 (each within the scatter of the next).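

In this assay, the saturated ring carbon next to the ring nitrogen had so far shown no response to a change of group, but compound 4 shows that it is not indifferent to what it carries: the replacement of 2-phenylethenyl by 3,4-dimethoxyphenyl gives a number 23.7 percentage points lower from compound 3 to compound 4 (beyond the scatter), and the replacement of phenyl by the same group gives a number 23.7 percentage points lower from compound 2 to compound 4 (beyond the scatter). Compound 1 carries the same 3,4-dimethoxyphenyl group, and methyl in place of hydrogen on an oxygen on an aromatic ring gives a number 28.9 percentage points lower from compound 1 to compound 4 (beyond the scatter), so the low number does not follow from 3,4-dimethoxyphenyl alone and appears here only with the methylated oxygen present. The data at hand offer no measurement that would account for either effect.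

As far as these compounds go, it remains open which part of 3,4-dimethoxyphenyl matters when the methylated oxygen is kept, as a phenyl with a single methoxy group or with two hydroxyl groups on the saturated ring carbon would show. From the compounds shown here alone, it is also open whether an ethyl group on the aromatic oxygen would bring a similar change to methyl.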